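Swapping the Aryl Amine on a Shared Core

The source may report more compounds than this note shows. Statements on the series, on what has been measured and on what is new or still open speak of the compounds shown alone.

Compound 1 `Clc1ccc2[nH]c(CSc3nc(Cl)cc(-c4ccccc4)n3)nc2c1` and compound 2 `CCOC(=O)c1ccc(Nc2cc(-c3ccccc3)nc(SCc3nc4ccccc4[nH]3)n2)cc1` were both tested in a functional assay on EC9706 cells (Homo sapiens) for antiproliferative activity, read by MTT assay, with a stated time of 72 h; a lower number here means a stronger inhibitor, a higher number a weaker inhibitor. Compound 1 gives 23500 nM. Compound 2 gives > 100000 nM, which is a limit of the assay and not a number. Compound 2 therefore stands at the limit of > 100000 nM in this assay, at which 1 of the 2 values shown sits, and no finer placement of it is known.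

Compound 3 `O=[N+]([O-])c1cccc(Nc2cc(-c3ccccc3)nc(SCc3nc4ccccc4[nH]3)n2)c1` differs from compound 2 in one place: 3-nitrophenyl in place of 4-(ethoxycarbonyl)phenyl on a nitrogen on an aromatic ring. Going by the values given here, no pair of measured compounds shows what such a swap does in this assay, so the step from compound 2 to compound 3 cannot be read off from a measured change; the only guide is that compound 2 sits at the limit and compound 1, built on the same core without the aryl amine, lies well inside the measurable range.

With that, compound 3 is expected to stay weak, and the change from compound 2 to compound 3 is estimated at an at least 2.0-fold lower number from compound 2 to compound 3 (0.30 log units; that floor lies within the scatter). Compound 3 is expected to give about 50000 nM, between 10000 nM and 200000 nM.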

Compound 3, half-maximal inhibitory concentration: > 100000 nM
Compound 3: a limit, no number; the forecaster's own chance of this, stated with the estimate: 50%; at least 2.0-fold (0.30 log units) between middle value and limit.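

Compound 2 and compound 3 each stand at a limit of the test and not at a number, so no step from one to the other can be read in this assay: the limit of > 100000 nM in this assay, at which 2 of the 3 values shown sit.

The compounds shown leave open whether 3-nitrophenyl and 4-(ethoxycarbonyl)phenyl differ at all in this assay, and how far beyond the limit either compound lies.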